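The source may report more compounds than this note shows. Statements on the series, on what has been measured and on what is new or still open speak of the compounds shown alone.

Compound 1 `Cc1ccc(-n2nc(C(=O)Nc3ccc(Oc4ncnc5[nH]ccc45)cc3)c(C)cc2=O)cc1` is the starting point; in a functional assay on A549 cells (Homo sapiens) for cytotoxicity, read by MTT assay, with a stated time of 72 h (on this read-out higher numbers stand for weaker inhibition and lower numbers for stronger inhibition), compound 1 gives 6400 nM. Compound 2 `Cc1cc(=O)n(-c2ccccc2OC(F)(F)F)nc1C(=O)Nc1ccc(Oc2ncnc3[nH]ccc23)cc1` gives 16200 nM in this assay, a change of 2-(trifluoromethoxy)phenyl in place of 4-methylphenyl on an aromatic nitrogen that made a 2.5-fold higher number from compound 1 to compound 2 (0.40 log units; beyond the scatter). Compound 3 `Cc1ccc(-n2nc(C(=O)Nc3ccc(Oc4ncnc5[nH]ccc45)c(F)c3)c(C)cc2=O)cc1` gives 18500 nM, where the change fluoro in place of hydrogen on an aromatic carbon made a 2.9-fold higher number from compound 1 to compound 3 (0.46 log units; beyond the scatter). Compound 4 `Cc1cc(=O)n(-c2ccccc2OC(F)(F)F)nc1C(=O)Nc1ccc(Oc2ncnc3[nH]ccc23)c(F)c1` carries both changes; it differs from compound 3 by 2-(trifluoromethoxy)phenyl in place of 4-methylphenyl on an aromatic nitrogen, the same change that turned compound 1 into compound 2, and its core differs from that of compound 1 as described for compound 3. Because a 2.5-fold higher number from compound 1 to compound 2 (0.40 log units; beyond the scatter) was modest, compound 4 is expected to show a step of about a 2.3-fold higher number from compound 3 to compound 4 (0.36 log units; beyond the scatter) in this assay. Compound 4 is therefore estimated at 42000 nM, likely between 18000 nM and 95000 nM.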

Compound 4, half-maximal inhibitory concentration: 16200 nM
For compound 4 the middle estimate is 2.6-fold (0.41 log units) above the measured one; the whole stated range lies above it.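

On the core of compound 3, the change to 2-(trifluoromethoxy)phenyl gives a 1.1-fold lower number from compound 3 to compound 4 (0.06 log units; within the scatter) in this assay, so the step seen on the core of compound 1 did not carry over: the same change on two cores in this assay, a 2.5-fold higher number (0.40 log units; beyond the scatter) from compound 1 to compound 2 and a 1.1-fold lower number (0.06 log units; within the scatter) from compound 3 to compound 4, 2.9-fold (0.46 log units) apart, beyond the scatter of two such steps. The fluoro change gives no change at the digits printed from compound 2 to compound 4 (within the scatter), and it did not carry over either: the same change on two cores in this assay, a 2.9-fold higher number (0.46 log units; beyond the scatter) from compound 1 to compound 3 and no change at the digits printed (within the scatter) from compound 2 to compound 4, 2.9-fold (0.46 log units) apart, beyond the scatter of two such steps. The two changes therefore do not add up in these four compounds, but this does not show why, nor whether the same holds for other changes or cores.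

The compounds shown leave open whether a phenyl ring bearing an amine or a carboxylic acid on the aromatic nitrogen would behave alike on both cores. They also leave open whether chloro in place of fluoro would give the same result.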